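This account rests on a few compounds, and the source may have more. Where it says the series, first, only, none or still open, it means among the compounds named here.

Working notes on the series in an assay on isolated protein for inhibition of Alpha glucosidase (Homo sapiens), with stated times of 5 min and 15 min, tested at 50 uM; on this read-out lower numbers stand for less inhibition and higher numbers for more inhibition at the one concentration tested (going by the name of the read-out). Compound 3 `O=C(C1=C(O)/C(=C/c2ccc(O)cc2)CCC1)c1ccccc1` gives 34.9%, and compound 1 `O=C(C1=C(O)/C(=C/c2ccc(O)c(O)c2)CCC1)c1ccccc1` gives 55.9%. The change hydroxy in place of hydrogen on an aromatic carbon made the step of a number 21 percentage points higher from compound 3 to compound 1 (beyond the scatter). Compound 2 `O=C1/C(=C/c2ccccc2)CCC/C1=C\c1cccc(O)c1` gives 65.1%; the difference between its core and the core of compound 3 is not broken down here. Compound 4 `O=C1/C(=C/c2ccccc2)CCC/C1=C\c1ccc(O)c(O)c1` is not yet measured in this assay and differs from compound 2 by hydroxy in place of hydrogen on an aromatic carbon. This is the same kind of change as from compound 3 to compound 1, though not the same: there the entering hydroxy sat meta to a large group, here it sits para to a large group. Among the compounds with values here, the step from compound 3 to compound 1, a number 21 percentage points higher from compound 3 to compound 1 (beyond the scatter), is the only measured instance of the change. On that basis a step of a number 14.9 percentage points higher from compound 2 to compound 4 (beyond the scatter) is expected. For compound 4 the expected number is 80%, estimated between 65% and 93%.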

Compound 4, a percentage reported as inhibition, at one concentration (the size of the read-out at that concentration, not a potency): 90.7%
Estimate against measurement, compound 4: 10.7 percentage points below; the range from low to high includes it.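

In this assay the added hydroxy carries over between the two cores, with a number 25.6 percentage points higher from compound 2 to compound 4 (beyond the scatter), and the size of the step does not differ from the earlier one: the same change on two cores in this assay, a number 21 percentage points higher (beyond the scatter) from compound 3 to compound 1 and a number 25.6 percentage points higher (beyond the scatter) from compound 2 to compound 4, 4.6 percentage points apart, within the scatter of two such steps. This rests on just two pairs, so it supports carrying the change between these two cores only and sets no rule for any other core. Each step is also read at one concentration, so neither shows how potency changes.

The compounds shown leave open whether a methoxy group, an amine or a fluorine atom in the place of the entering hydroxy would give a similar step. They also leave open what a carboxylic acid on the same ring would do.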